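The compounds below may be only part of what the source reports. "The series", "measured", "known", "first", "only" and "open" are said of these compounds alone.

Working notes on the series, read in a physicochemical assay for lipophilicity; a lower number here means a more polar compound, a higher number a more lipophilic compound. Compound 1 `CCCCCCS(=O)(=O)c1ccc(O)c(C(=O)Nc2ccc(Br)cc2)c1` gives 3.2, compound 2 `CCCCCCCCCCS(=O)(=O)c1ccc(O)c(C(=O)Nc2ccc(Br)cc2)c1` gives 5.36 and compound 3 `CCCCCCCCCCCCS(=O)(=O)c1ccc(O)c(C(=O)Nc2ccc(Br)cc2)c1` gives 6.49. Compound 2 therefore holds the middle of the three numbers, beyond the scatter from each of the other two.

Compound 4 `CCCCCCCCCCS(=O)(=O)c1ccc(O)c(C(=O)Nc2ccc(C(F)(F)F)cc2)c1` keeps the chain of compound 2 and differs only on the aromatic ring: trifluoromethyl in place of bromo on an aromatic carbon. This is trifluoromethyl in place of bromo on an aromatic carbon, para to a large group.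

The measured steps are all large: a number 2.16 log units higher from compound 1 to compound 2 (beyond the scatter), a number 1.13 log units higher from compound 2 to compound 3 (beyond the scatter) and a number 3.29 log units higher from compound 1 to compound 3 (beyond the scatter). All three are changes in the saturated chain, however, and none touches this aromatic carbon. They set no size for the present change, and the series holds no measured change at this position. No step beyond the scatter is expected in this assay, in either direction, though that expectation is not tested by any measured pair.

The expected change is a number 0.04 log units higher from compound 2 to compound 4 (within the scatter). The estimate for compound 4 is 5.4, with an expected range of 4.9 to 5.9.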

Compound 4, distribution coefficient: 6.34
Estimate against measurement, compound 4: 0.94 log units below, and the stated range ends below it.
By their numbers in this assay, from the lowest: compound 1; then compound 2; then compounds 4 and 3 (each within the scatter of the next).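

With the chain held as in compound 2, trifluoromethyl in place of bromo gives, in this assay, a number 0.98 log units higher from compound 2 to compound 4 (beyond the scatter). Among the compounds shown here, this is the only measured change at this aromatic carbon, and it shows that the position, para to a large group, can move the read-out beyond the scatter, so the saturated chain is not the only place that does. Nothing measured here bears on why the number moves at this position.

A single pair leaves open whether a step of this size would hold with the shorter chain of compound 1 or the longer chain of compound 3. It also leaves open how other groups on this carbon, such as chloro, methoxy, nitrile or a carboxylic acid, would read against bromo.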